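Swapping Benzyl for 2-Fluorophenyl on a Thiourea Nitrogen

A few compounds are considered here, and "the series" means these few. Any claim that something is new, unique, unknown or untested is made for them only; others in the source may bear on it.

Measured compounds:
compound 1, `O=C(NNC(=S)NCc1ccccc1)c1cc([N+](=O)[O-])c[nH]1`, 397000 nM
compound 2, `COc1ccc(NC(=S)NNC(=O)c2cc([N+](=O)[O-])c[nH]2)cc1`, 331000 nM
compound 3, `Cn1cc([N+](=O)[O-])cc1C(=O)NNC(=O)NCc1ccco1`, 482000 nM

Of the compounds shown here, three sharing a nitropyrrole-type carbohydrazide core have been tested in an ADME assay on Vero cells (Chlorocebus sabaeus) for cytotoxicity, read by MTT assay, with a stated time of 72 h; a lower number here means a stronger inhibitor, a higher number a weaker inhibitor. Compound 1 gives 397000 nM, compound 2 gives 331000 nM and compound 3 gives 482000 nM. Compound 1 has the second highest of the three numbers, but all three values sit within the usual scatter of one another, so no ordering among them can be read from these data.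

Compound 4, `O=C(NNC(=S)Nc1ccccc1F)c1cc([N+](=O)[O-])c[nH]1`, is derived from compound 1 by a single change: 2-fluorophenyl in place of benzyl on an amide-type nitrogen. Compound 2 already carries an aryl group on the same amide-type nitrogen and gives 331000 nM, a number indistinguishable from that of compound 1. On that basis the step from compound 1 to compound 4 is expected to be small, in no particular direction, and to stay within the scatter, as a 1.1-fold lower number from compound 1 to compound 4 (0.04 log units; within the scatter) shows. Compound 4 is therefore estimated at 360000 nM in this assay, with a range from 180000 nM to 700000 nM.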

Compound 4, half-maximal inhibitory concentration: 471000 nM
Estimate against measurement, compound 4: 1.3-fold (0.12 log units) below; the measured number falls inside the stated range.
By their numbers in this assay, from the lowest: compounds 2, 1, 4 and 3 (each within the scatter of the next).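

In this assay, within the data shown here, putting 2-fluorophenyl in place of benzyl on the amide-type nitrogen gives a 1.2-fold higher number from compound 1 to compound 4 (0.07 log units; within the scatter), so this position now has a direct one-place step, which the earlier compounds did not provide. At this level of scatter, the exchange of these two groups on this nitrogen shows no measurable difference, and this single pair can say no more than that. No supporting measurement bears on this result.

The compounds shown leave open whether a longer chain, such as phenylpropyl, or a group of another kind, such as an amine or a carboxylic acid, on this nitrogen would move the number beyond the scatter. They also leave open what plain phenyl would give here, a comparison that would isolate the fluorine from the rest of the change.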